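Amide nitrogen substituents in an antiproliferative series

A few compounds are considered here, and "the series" means these few. Any claim that something is new, unique, unknown or untested is made for them only; others in the source may bear on it.

Compound 1 `CCN(CC)CCNC(=O)c1ccc(C(CC)(CC)c2ccc(OCS(=O)(=O)c3ccccc3)c(C)c2)n1CC`: in a functional assay on BXPC-3 cells (Homo sapiens) for antiproliferative activity, read by MTT assay, with a stated time of 24 h (on this read-out lower numbers stand for stronger inhibition and higher numbers for weaker inhibition), compound 1 gives 6270 nM.
Compound 2 `CCn1c(C(=O)N[C@@H](CO)CCO)ccc1C(CC)(CC)c1ccc(OCS(=O)(=O)c2ccccc2)c(C)c1`: in this assay compound 2 reaches only > 50000 nM, which is a limit of the assay rather than a number.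

Within the data shown here, compound 1 stands as the single numerical value in this set; the other entry is a limit. Among the measured compounds shown here, the one measured change on the amide-type nitrogen is an at least 7.9-fold higher number from compound 1 to compound 2 (0.90 log units; beyond the scatter), where 3-hydroxy-1-(hydroxymethyl)propyl took the place of 2-(diethylamino)ethyl and the read-out went to the limit (the limit of > 50000 nM in this assay, at which 1 of the 2 values shown sits). That step bears directly on compound 3 `CCn1c(C(=O)N[C@H](C(=O)O)C(C)C)ccc1C(CC)(CC)c1ccc(OCS(=O)(=O)c2ccccc2)c(C)c1`, which differs from compound 1 by 1-carboxy-2-methylpropyl in place of 2-(diethylamino)ethyl on an amide-type nitrogen. As in compound 2, the 2-(diethylamino)ethyl group is removed, so a weakening of comparable size is expected, a 6.4-fold higher number from compound 1 to compound 3 (0.80 log units; beyond the scatter). Compound 3 is therefore estimated at 40000 nM, in the range 12000 nM to 100000 nM, with a real chance that only a limit is reported.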

Compound 3, half-maximal inhibitory concentration: 16200 nM
The estimate for compound 3 lay 2.5-fold (0.39 log units) above the measured number; low and high end bracket the measured number.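

Losing the 2-(diethylamino)ethyl group does not by itself take the series to the limit: in this assay the move to 1-carboxy-2-methylpropyl gives a 2.6-fold higher number from compound 1 to compound 3 (0.41 log units; beyond the scatter) and still leaves a measurable number. What enters on the amide-type nitrogen therefore matters as well as what leaves, since the two replacements differ, with an at least 3.0-fold lower number from compound 2 to compound 3 (0.48 log units; beyond the scatter) on exchanging 3-hydroxy-1-(hydroxymethyl)propyl for 1-carboxy-2-methylpropyl. The entry for compound 2 is a limit and not a number: the limit of > 50000 nM in this assay, at which 1 of the 3 values shown sits.

The compounds shown leave open whether the carboxylic acid itself or the branched carbon chain of 1-carboxy-2-methylpropyl accounts for the gap to compound 2. Also open, on these data alone, is how the methyl ester of compound 3, or a longer chain ending in a diethylamino group, would read in this assay on the same nitrogen.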